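Ring closure of the basic side chain on compound 1

The compounds below may be only part of what the source reports. "The series", "measured", "known", "first", "only" and "open" are said of these compounds alone.

Measured so far:
compound 1, `CCN(CC)CCNc1cc(C)c2cc(NC(=O)c3ccc(Cl)c(Cl)c3)ccc2n1`: 1420 nM
compound 2, `CCN1CCN(c2cc(C)c3cc(NC(=O)c4ccc(F)c(F)c4)ccc3n2)CC1`: 5230 nM
compound 3, `CCN1CCN(c2cc(C)c3cc(NC(=O)c4ccccc4)ccc3n2)CC1`: 14200 nM

Three compounds sharing one core were measured in a functional assay on MCF7 cells (Homo sapiens) for antiproliferative activity, read by MTT assay, with a stated time of 72 h; a lower number here means a stronger inhibitor, a higher number a weaker inhibitor. Compound 1 gives the lowest number of the three; compound 2 stands nearest to it, with a number higher by a margin beyond the scatter, and compound 3 stands furthest. Going by the values given here, the only single-point step among the measured compounds is a 2.7-fold higher number from compound 2 to compound 3 (0.43 log units; beyond the scatter), which concerns the group on the carbonyl carbon, not the basic side chain.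

Compound 4, `Cc1cc(NCCN2CCCCC2)nc2ccc(NC(=O)c3ccc(Cl)c(Cl)c3)cc12`, differs from compound 1 in one place: piperidin-1-yl in place of diethylamino on a saturated chain carbon, two bonds along the chain from a nitrogen on an aromatic ring. Among the compounds with values here, no measured step touches this part of the molecule, so nothing among the measured compounds tells how the change should read in this assay. With no evidence either way, compound 4 is expected to stay close to compound 1, a step of a 1.0-fold lower number from compound 1 to compound 4 (0.01 log units; within the scatter) that is not expected to exceed the scatter. The estimate for compound 4 is therefore 1400 nM, within a range of 550 nM to 3600 nM.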

Compound 4, half-maximal inhibitory concentration in the MCF7 assay: 1190 nM
The estimate for compound 4 lay 1.2-fold (0.07 log units) above the measured number; low and high end bracket the measured number.
By their numbers in the MCF7 assay, from the lowest: compounds 4 and 1 (each within the scatter of the next); then compound 2; then compound 3.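

In the MCF7 assay the side chain end takes piperidin-1-yl in place of diethylamino with no change beyond the scatter (a 1.2-fold lower number from compound 1 to compound 4 (0.08 log units; within the scatter)), so at this place on the saturated chain, closing the open amine into a six-membered ring leaves the antiproliferative reading as it was. In a physicochemical assay for solubility (a lower number here means a less soluble compound, a higher number a more soluble compound), compound 1 gives 95.2 ug/mL and compound 4 gives 70.8 ug/mL and this read-out also stays within the scatter (a 1.3-fold lower number from compound 1 to compound 4 (0.13 log units; within the scatter)). Nothing available gives a reason for this outcome.

Still open, on these data alone, is whether a morpholin-4-yl or pyrrolidin-1-yl group at the same place would read the same way, or whether a longer chain carrying the piperidin-1-yl group would. The compounds shown also leave open whether the same swap holds with a benzamide other than the 3,4-dichlorophenyl one.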